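Shortening the hydroxyalkoxy chain: compound 1 to compound 4

The source may hold more compounds than are shown below. What is called first, only, known or untested is meant among the compounds shown, and "the series" means these compounds.

compound 1 `COc1ncc(-c2ccc3ncnc(Nc4ccc(OCCCO)nc4)c3c2)cc1NS(=O)(=O)c1ccc(F)cc1F` — 3680 nM
compound 2 `COc1ncc(-c2ccc3ncnc(Nc4cnn(CC(=O)O)c4)c3c2)cc1NS(=O)(=O)c1ccc(F)cc1F` — 1540 nM
compound 3 `COc1ncc(-c2ccc3ncnc(Nc4ccc(OCCO)c(Cl)c4)c3c2)cc1NS(=O)(=O)c1ccc(F)cc1F` — 7320 nM

In a functional assay on HCT-116 cells (Homo sapiens) for antiproliferative activity, read by sulforhodamine B assay, with a stated time of 72 h (on this read-out higher numbers stand for weaker inhibition and lower numbers for stronger inhibition), compound 1 gives 3680 nM, the second highest of the three numbers. The nearest neighbour lies within the scatter (a 2.0-fold higher number from compound 1 to compound 3 (0.30 log units; within the scatter)), whereas the step to the lowest number is modest but real (a 2.4-fold lower number from compound 1 to compound 2 (0.38 log units; beyond the scatter)). Compound 4 `COc1ncc(-c2ccc3ncnc(Nc4ccc(OCCO)nc4)c3c2)cc1NS(=O)(=O)c1ccc(F)cc1F` differs from compound 1 by hydroxy in place of hydroxymethyl on a saturated chain carbon, two bonds along the chain from an oxygen on an aromatic ring. Going by the values given here, no measured step alters this chain alone; the only step that touches it also swaps the whole aromatic group and stays within the scatter. The change in this assay from compound 1 to compound 4 is therefore expected to be a 1.0-fold higher number from compound 1 to compound 4 (0.00 log units; within the scatter), nothing beyond the scatter. Compound 4 is estimated at 3700 nM, ranging from 1500 nM to 9000 nM.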

Compound 4, half-maximal inhibitory concentration: 2340 nM
The estimate for compound 4 lay 1.6-fold (0.20 log units) above the measured number; the measured number falls inside the stated range.
By their numbers in this assay, from the lowest: compounds 2, 4, 1 and 3 (each within the scatter of the next, the first and the last beyond it).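

In this assay, 2-hydroxyethoxy in place of 3-hydroxypropoxy gives a 1.6-fold lower number from compound 1 to compound 4 (0.20 log units; within the scatter) and so shows the effect of this chain change alone: the number does not move beyond the scatter. With the 2-hydroxyethoxy chain kept, the 6-(2-hydroxyethoxy)pyridin-3-yl group gives a 3.1-fold lower number from compound 3 to compound 4 (0.50 log units; beyond the scatter) in place of 3-chloro-4-(2-hydroxyethoxy)phenyl, but a 1.5-fold higher number from compound 2 to compound 4 (0.18 log units; within the scatter) in place of 1-(carboxymethyl)-1H-pyrazol-4-yl. No evidence is available to explain these steps. From the compounds shown here alone, whether a longer chain, or an amine in place of the hydroxy, would shift the number remains open.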